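A few compounds are considered here, and "the series" means these few. Any claim that something is new, unique, unknown or untested is made for them only; others in the source may bear on it.

Notes on the series in an ADME assay on BJ cells (Homo sapiens) for cytotoxicity, read by CellTiter-Glo and resazurin assay, with a stated time of 72 h; on this read-out lower numbers stand for an effect already at smaller amounts and higher numbers for an effect only at larger amounts of compound.

Compound 1 `COc1ccc(F)c(-c2ccc(C(=O)N(Cc3cccc(OCCCCCC(=O)O)c3)C(C)C)cc2)c1` is read in this assay only as a limit, > 26000 nM. Compound 2 `CC(C)N(Cc1cccc(OCCCCCC(=O)O)c1)C(=O)c1ccc(-c2cccc(Cl)c2)cc1` is likewise read only as a limit, > 21900 nM. The step that the two limits leave unreadable from compound 1 to compound 2 is therefore unreadable, since both of its ends sit at a limit. Compound 3 `CCOC(=O)CCCCCOc1cccc(CN(C(=O)c2ccc(-c3cccc4ccccc34)cc2)C(C)C)c1` also stands at a limit in this assay, > 26000 nM. Within the data shown here, none of the three measured values is a number: one sits at the limit of > 21900 nM in this assay, at which 1 of the 3 values shown sits, and two sit at the limit of > 26000 nM in this assay, at which 2 of the 3 values shown sit, so no measured step of readable size exists anywhere.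

Compound 4 `CCOC(=O)CCCCCOc1cccc(CN(C(=O)c2ccc(-c3cccc(OC)c3)cc2)C(C)C)c1` differs from compound 3 by 3-methoxyphenyl in place of naphthalen-1-yl on an aromatic carbon. Among the measured compounds shown here, the only step that touches a change on an aromatic carbon of a biaryl, from compound 1 to compound 2, gives no size, and no measured value offers a scale for the present change. The expectation for compound 4 is therefore no step beyond the scatter, a number no higher from compound 3 to compound 4 (the limit leaves the size open). Compound 4 is expected at 26000 nM in this assay, with an estimated range of 13000 nM to 52000 nM, most probably reported again only as a limit.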

Compound 4, half-maximal effective concentration: > 21000 nM
Compound 4 was reported as a limit (the forecaster's own chance of this, stated with the estimate: 85%); the middle value does not contradict the limit.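

Compound 3 and compound 4 are both read only as limits in this assay, so the step between them cannot be read. All values shown are limits, and the compounds shown leave open whether any change on an aromatic carbon alters the half-maximal effective concentration at all.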